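Hydroxy for methoxy on the dimethylamino-bearing analogue

The source may report more compounds than this note shows. Statements on the series, on what has been measured and on what is new or still open speak of the compounds shown alone.

Measured compounds in a functional assay on SF-539 cells (Homo sapiens) for inhibition, read by sulforhodamine B assay, with a stated time of 48 h; a higher number here means a weaker inhibitor of growth, a lower number a stronger inhibitor of growth:
- compound 1, `Cc1cc(O)cc(-c2nn(CC#N)cc2-c2ccnc(-c3ccc(Oc4ccccc4)cc3)c2)c1`, gives 13500 nM
- compound 2, `COc1cc(C)cc(-c2nn(CC#N)cc2-c2ccnc(-c3ccc(N(C)C)cc3)c2)c1`, gives 596 nM

Compound 2 holds the lowest of the two numbers; the gap to compound 1 is well beyond the scatter, so compound 2 is the stronger growth inhibitor of the pair. The two differ at more than one place, so the gap cannot be assigned to a single change.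

Compound 3, `Cc1cc(O)cc(-c2nn(CC#N)cc2-c2ccnc(-c3ccc(N(C)C)cc3)c2)c1`, keeps the dimethylamino-bearing aryl of compound 2 and alters only the other ring: hydrogen in place of methyl on an oxygen on an aromatic ring, methoxy to hydroxy. Within the data shown here, no measured pair isolates this change. The expectation is therefore a step of no more than modest size in this assay, with the direction uncertain and a wider spread than the scatter alone would give; the expected step is a 1.3-fold higher number from compound 2 to compound 3 (0.13 log units; within the scatter).

For compound 3 the estimate in this assay is 800 nM, with a range from 300 nM to 2500 nM.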

Compound 3, concentration for total growth inhibition: 5330 nM
The estimate for compound 3 lay 6.7-fold (0.82 log units) below the measured number; measured number above the stated range.
By their numbers in this assay, from the lowest: compound 2; then compound 3; then compound 1.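

In this assay, among these compounds, the first reading that isolates this change shows that the methyl on an oxygen on an aromatic ring counts: hydrogen in its place, methoxy to hydroxy, gives an 8.9-fold higher number from compound 2 to compound 3 (0.95 log units; beyond the scatter). With the hydroxy kept, dimethylamino in place of phenoxy on an aromatic carbon gives a 2.5-fold lower number from compound 1 to compound 3 (0.40 log units; beyond the scatter), so the aryl substituent also moves the number, though by a smaller step than the one at the oxygen in these two readings. No measurement shown here accounts for either step.

Open, going by these compounds, is whether the step at the oxygen keeps its size with phenoxy in place of dimethylamino, since it has been read only on the dimethylamino-bearing aryl, and whether the phenoxy to dimethylamino step holds with methoxy in place of hydroxy. Also open, on these data alone, is how this position responds to a longer chain on the oxygen, such as ethoxy, or to an amine in place of the oxygen group.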